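A few compounds are considered here, and "the series" means these few. Any claim that something is new, unique, unknown or untested is made for them only; others in the source may bear on it.

Three compounds share one core and differ only in the group on the amine nitrogen in the ring. Compound 1 `CC(C)N1CCN(Cc2csc(N)c2C(=O)c2ccc(Cl)cc2)CC1` carries an isopropyl there; in a functional assay on CHO cells with adenosine receptor A1 (Homo sapiens) as the target, read by cAMP accumulation and immunoassay, with a stated time of 6 min, tested at 0.01 uM (on this read-out higher numbers stand for a weaker effect at the one concentration tested and lower numbers for a stronger effect), compound 1 gives -1%. Compound 2 `Nc1scc(CN2CCN(c3ccc(Cl)cc3Cl)CC2)c1C(=O)c1ccc(Cl)cc1` gives 2%, and compound 3 `Nc1scc(CN2CCN(c3ccc(Cl)cc3F)CC2)c1C(=O)c1ccc(Cl)cc1` gives -9.2%. On these numbers compound 3 has the lowest reading of the three, but the gap from compound 1 is small, a number 8.2 percentage points lower from compound 1 to compound 3 (within the scatter), while the gap from compound 2 is a number 11.2 percentage points lower from compound 2 to compound 3 (beyond the scatter). Replacing the isopropyl by a substituted phenyl also changed little, as a number 3 percentage points higher from compound 1 to compound 2 (within the scatter) shows. Compound 4 `Nc1scc(CN2CCN(c3cccc(C(F)(F)F)c3)CC2)c1C(=O)c1ccc(Cl)cc1` is the next member: 3-(trifluoromethyl)phenyl in place of 4-chloro-2-fluorophenyl on an amine nitrogen in a ring. Because a number 3 percentage points higher from compound 1 to compound 2 (within the scatter) and a number 8.2 percentage points lower from compound 1 to compound 3 (within the scatter) both stayed within the scatter, and a number 11.2 percentage points lower from compound 2 to compound 3 (beyond the scatter) was only modest, the expected step in this assay is a number 6.2 percentage points higher from compound 3 to compound 4 (within the scatter), with no move beyond the scatter in either direction. Compound 4 is therefore estimated at -3%, with a range from -14% to 9%.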

Compound 4, a percentage reported as activity, at one concentration (the size of the read-out at that concentration, not a potency): -8.2%
Estimate against measurement, compound 4: 5.2 percentage points above; low and high end bracket the measured number.
By their numbers in this assay, from the lowest: compounds 3, 4, 1 and 2 (each within the scatter of the next, the first and the last beyond it).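

At this position on the amine nitrogen, 3-(trifluoromethyl)phenyl cannot be told apart from 4-chloro-2-fluorophenyl in this assay, with a number 1 percentage points higher from compound 3 to compound 4 (within the scatter) even though the entering group carries different substituents and has more heavy atoms. Compound 2 now stands apart from two other compounds instead of one, with a number 10.2 percentage points lower from compound 2 to compound 4 (beyond the scatter) as a second modest gap, while the isopropyl of compound 1 still cannot be separated from this new phenyl group, with a number 7.2 percentage points lower from compound 1 to compound 4 (within the scatter) as the step. No supporting data are available to explain why the 2,4-dichlorophenyl compound differs. All these readings come from one concentration, so they do not give potency. As far as these compounds go, whether a methoxy group on the phenyl ring, an unsubstituted phenyl or a carboxylic acid at this position would shift the reading remains open.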